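Replacing an amine link with an amide in sulfonamide piperidines

The compounds below may be only part of what the source reports. "The series", "measured", "known", "first", "only" and "open" are said of these compounds alone.

Compound 1 `Cc1cc(C)c(S(=O)(=O)N2CCC(c3ccccc3)CC2)c(C)c1` sits at a limit of a functional assay on DLD-1 cells (Homo sapiens) for antiproliferative activity, read by CellTiter-Glo, with a stated time of 72 h (on this read-out higher numbers stand for weaker inhibition and lower numbers for stronger inhibition), giving > 5000 nM; this is a limit, not a number (the limit of > 5000 nM in this assay, at which 1 of the 3 values shown sits).
Compound 2 `Cc1cc(C)c(S(=O)(=O)N2CCC(N3CCN(C)CC3)CC2)c(C)c1` gives 1100 nM in this assay.
Compound 3 `Cc1cc(C)c(S(=O)(=O)N2CCC(N3CCC(C(C)C)CC3)CC2)c(C)c1` gives 0.3 nM in this assay.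

Compound 3 has the lowest of the two numbers shown, and the nearest measured neighbour is compound 2, with a 3700-fold lower number from compound 2 to compound 3 (3.56 log units; beyond the scatter). Against compound 1 the gap is even wider: an at least 16000-fold lower number from compound 1 to compound 3 (4.22 log units; beyond the scatter). The move from compound 1 to compound 2 was smaller, an at least 4.5-fold lower number from compound 1 to compound 2 (0.65 log units; beyond the scatter).

Compound 4 `Cc1cc(C)c(S(=O)(=O)N2CCC(C(=O)N3CCC(C)CC3)CC2)c(C)c1` differs from compound 3 in one place: (4-methylpiperidin-1-yl)carbonyl in place of 4-isopropylpiperidin-1-yl on a saturated ring carbon. Going by the values given here, the group that leaves is the same one whose arrival produced the two large drops just described, so the steps that bear on this change are those from compound 1 and from compound 2 to compound 3. Among the compounds with values here, the group that enters shares the ring and the single hydrogen-bond acceptor, but connects through a carbonyl rather than through the ring nitrogen, and no measured pair shows what such a carbonyl link does here.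

The expectation is therefore a large rise in the number, back towards the range of compound 2, though with wide uncertainty in both directions. Compound 4 is estimated at 500 nM, expected to fall between 20 nM and 5000 nM, which means an expected step of a 1700-fold higher number from compound 3 to compound 4 (3.22 log units; beyond the scatter).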

Compound 4, half-maximal inhibitory concentration: > 5000 nM
Compound 4: no number, only a limit (the forecaster's own chance of this, stated with the estimate: 25%); at least 10-fold (1.00 log units) between middle value and limit.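

In this assay compound 4 gives > 5000 nM, which is a limit and not a number, and it is the second compound to stop there: the limit of > 5000 nM in this assay, at which 2 of the 4 values shown sit.

Putting (4-methylpiperidin-1-yl)carbonyl in place of 4-isopropylpiperidin-1-yl on this saturated ring carbon gives an at least 16000-fold higher number from compound 3 to compound 4 (4.22 log units; beyond the scatter), so at this position a matching count of heavy atoms, the same kind of six-membered ring and the same count of hydrogen-bond acceptors are not enough to keep the low number. Compound 4 also falls behind the much weaker amine-linked compound, with an at least 4.5-fold higher number from compound 2 to compound 4 (0.65 log units; beyond the scatter), which shows that the carbonyl-linked group gives up even the modest gain that 4-methylpiperazin-1-yl showed over phenyl.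

The step from compound 1 to compound 4 cannot be read, as both ends are limits. This change also swaps the link and the ring's side group together, so the compounds shown do not tell which of the two matters more; (4-isopropylpiperidin-1-yl)carbonyl, which keeps the isopropyl group and carries the carbonyl link, or 4-methylpiperidin-1-yl, which keeps the direct link and carries the methyl group, would separate them.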